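This account rests on a few compounds, and the source may have more. Where it says the series, first, only, none or still open, it means among the compounds named here.

Measured so far:
- compound 1 `CCOC(=O)Cn1cc(CNCCN2CCN(C)CC2)c(-c2ccccc2C)n1`: > 20000 nM in an ADME assay on Huh-7 cells (Homo sapiens) for cytotoxicity; a lower number here means that less compound is tolerated, a higher number that more compound is tolerated
- compound 2 `CN1CCN(CCNCc2cn(-c3ccc(C(F)(F)F)cc3)nc2-c2ccc(Cl)cc2)CC1`: 3000 nM
- compound 3 `CN1CCN(CCNCc2cn(-c3ccc(C(F)(F)F)cc3)nc2-c2ccc(OC(F)(F)F)cc2)CC1`: 3000 nM

The value of compound 1 in this assay is a limit of the assay, not a number, as the line the limit of > 20000 nM in this assay, at which 1 of the 3 values shown sits, records. Among the measured compounds shown here, compound 2 and compound 3 each give a number, and the one step between them, no change at the digits printed from compound 2 to compound 3 (within the scatter), lies within the scatter. Compound 4 `Cc1ccccc1-c1nn(-c2ccc([N+](=O)[O-])cc2)cc1CNCCN1CCN(C)CC1` is not yet measured. It differs from compound 1 by 4-nitrophenyl in place of (ethoxycarbonyl)methyl on an aromatic nitrogen. The measured step changes a group on a different ring, so it does not bear directly on this change. For the measured compounds named here, compound 2 and compound 3, which carry an aryl group on the same aromatic nitrogen, both give numbers where compound 1 gives only a limit; since no step between compound 1 and either of them is available, only these values can guide the estimate. Compound 4 is therefore expected to move toward a measurable value, with the step of an at least 3.3-fold lower number from compound 1 to compound 4 (0.52 log units; beyond the scatter) estimated from compound 1. The estimate for compound 4 is 6000 nM, within 2500 nM to 20000 nM.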

Compound 4, half-maximal cytotoxic concentration: > 20000 nM
Compound 4 ended at the assay's limit; the forecaster's own chance of this, stated with the estimate: 25%; middle value at least 3.3-fold (0.52 log units) away from the limit.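

In this assay, compound 1 and compound 4 both stand at a limit of the assay rather than at a number, so no step between them can be read: the limit of > 20000 nM in this assay, at which 2 of the 4 values shown sit.

The compounds shown leave open whether 4-nitrophenyl in place of (ethoxycarbonyl)methyl on the aromatic nitrogen changes this read-out at all.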